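Trimethoxyphenyl for Methylphenyl: Expected Tolerance of Compound 3

The source may report more compounds than this note shows. Statements on the series, on what has been measured and on what is new or still open speak of the compounds shown alone.

Compound 1, `Cc1ccc(CNC(=O)c2nc(C(C)(C)NC(=O)OCc3ccccc3)nc(O)c2O)cc1`: 234000 nM
Compound 2, `COCCCNC(=O)c1nc(C(C)(C)NC(=O)OCc2ccccc2)nc(O)c1O`: 259000 nM

In an ADME assay on C8166 cells (Homo sapiens) for cytotoxicity, read by MTT assay, with a stated time of 3 days (a lower number here means that less compound is tolerated, a higher number that more compound is tolerated), compound 1 gives 234000 nM, the lowest of the two numbers, while compound 2 gives 259000 nM. For the measured compounds named here, the one measured step, a 1.1-fold higher number from compound 1 to compound 2 (0.04 log units; within the scatter), swaps the same group and stayed within the scatter. Compound 3, `COc1cc(CNC(=O)c2nc(C(C)(C)NC(=O)OCc3ccccc3)nc(O)c2O)cc(OC)c1OC`, is not yet measured; it differs from compound 1 by 3,4,5-trimethoxyphenyl in place of 4-methylphenyl on a saturated chain carbon bound to an amide-type nitrogen. Going by the values given here, since the only comparable step was within the scatter, no step beyond the scatter is expected in this assay. Compound 3 is therefore expected to give 230000 nM, between 110000 nM and 480000 nM, a step of a 1.0-fold lower number from compound 1 to compound 3 (0.01 log units; within the scatter).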

Compound 3, half-maximal cytotoxic concentration: 110000 nM
Beside the measured number, compound 3's estimate is 2.1-fold (0.32 log units) above it; the measured number falls inside the stated range.
By their numbers in this assay, from the lowest: compound 3; then compounds 1 and 2 (each within the scatter of the next).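

In this assay, the group on a saturated chain carbon bound to an amide-type nitrogen can shift the number beyond the scatter: 3,4,5-trimethoxyphenyl gives a 2.1-fold lower number from compound 1 to compound 3 (0.33 log units; beyond the scatter) and a 2.4-fold lower number from compound 2 to compound 3 (0.37 log units; beyond the scatter), both modest steps. The earlier exchange of 4-methylphenyl for 2-methoxyethyl had stayed within the scatter, so this place is not indifferent to every change. Nothing available explains this shift.

On these data alone, it remains open whether a phenyl ring with a single methoxy group would give the same step, and how an amine or a carboxylic acid at this place would read.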